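A few compounds are considered here, and "the series" means these few. Any claim that something is new, unique, unknown or untested is made for them only; others in the source may bear on it.

Working notes on the series. In a functional assay on SW-620 cells (Homo sapiens) for cytotoxicity, read by MTT assay, with a stated time of 72 h (a lower number here means a stronger inhibitor, a higher number a weaker inhibitor), compound 1 (`O=C1CS/C(=N\c2csc(-c3ccccc3)c2)N1`) gives only a limit, > 50000 nM, and not a number. For compound 2 (`COc1cccc(N2C(=O)CS/C2=N\c2csc(-c3ccccc3)c2)c1`) this assay shows "not determined" (no result reported), so compound 2 has no single number to stand on. For the measured compounds named here, the only value shown for the series is the limit seen for compound 1 (the limit of > 50000 nM in this assay, at which 1 of the 2 values shown sits), and no measured step exists against which to place it. Compound 3 (`COc1cccc(N2C(=O)CS/C2=N\c2csc(-c3ccc(Cl)cc3)c2)c1`) is the next compound to be run. It differs from compound 2 by chloro in place of hydrogen on an aromatic carbon. Going by the values given here, with no measured step, no size or direction can be read for this change; any shift beyond the scatter of this assay is unsupported, and the one value seen for compound 1 points to weak inhibition. Compound 3 is therefore expected to give about 40000 nM in this assay, within a range of 10000 nM to 100000 nM, with a real chance that only a limit is reported.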

Compound 3, half-maximal inhibitory concentration: 33000 nM
Beside the measured number, compound 3's estimate is 1.2-fold (0.08 log units) above it; the measured number falls inside the stated range.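

No new step can be read in this assay: compound 3 gives 33000 nM, but compound 2 has no number to set against it. The compounds shown leave open what size and direction the change from phenyl to 4-chlorophenyl has in this series.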